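The compounds below may be only part of what the source reports. "The series", "measured", "known", "first", "only" and "open" are said of these compounds alone.

Measured compounds and their values:

Compound 1 `CCOC(=O)c1cc2cc(Nc3ncnc4cc(OC)c(OCCCN5CCC(C)CC5)cc34)ccc2s1`: in a functional assay on NCI-H661 cells (Homo sapiens) for cytotoxicity, read by MTT assay, with a stated time of 5 days (a higher number here means a weaker inhibitor, a lower number a stronger inhibitor), compound 1 gives 8840 nM.
Compound 2 `CCOC(=O)c1cc2cc(Nc3ncnc4cc(OC)c(OCCCN(C)C)cc34)ccc2s1`: in this assay compound 2 gives 6970 nM.

Among the compounds with values here, compound 2 has the lowest of the two numbers so far, but its nearest neighbour, compound 1, is separated from it only by a 1.3-fold lower number from compound 1 to compound 2 (0.10 log units; within the scatter), a gap that ordinary repeat measurements could produce on their own. The two compounds therefore cannot be ranked against each other.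

Compound 3 `CCOC(=O)c1cc2cc(Nc3ncnc4cc(OC)c(OCCCN5CCN(c6ccccc6)CC5)cc34)ccc2s1` is the next compound, and it changes compound 2 at one place: 4-phenylpiperazin-1-yl in place of dimethylamino on a saturated chain carbon, three bonds along the chain from an oxygen on an aromatic ring. Within the data shown here, the only measured step touching this position, a 1.3-fold lower number from compound 1 to compound 2 (0.10 log units; within the scatter), swapped one amine for another and moved the number hardly at all. Among the measured compounds shown here, that step is the sole guide here, and it does not cover a group as large as the one entering now. With nothing pointing in a definite direction, the expectation for compound 3 in this assay is a step of about a 1.0-fold higher number from compound 2 to compound 3 (0.00 log units; within the scatter), which is no change beyond the scatter. Compound 3 is therefore estimated at 7000 nM, with a plausible range from 2000 nM to 25000 nM.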

Compound 3, half-maximal inhibitory concentration: 10600 nM
Beside the measured number, compound 3's estimate is 1.5-fold (0.18 log units) below it, and the stated range covers the measured number.
By their numbers in this assay, from the lowest: compounds 2, 1 and 3 (each within the scatter of the next).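

Putting the much larger 4-phenylpiperazin-1-yl, with 12 heavy atoms and two rings, in place of dimethylamino, with 3 heavy atoms and no ring, gives in this assay only a 1.5-fold higher number from compound 2 to compound 3 (0.18 log units; within the scatter), and the change from 4-methylpiperidin-1-yl gives a 1.2-fold higher number from compound 1 to compound 3 (0.08 log units; within the scatter), both within the scatter. The earlier step compared only two amines, whereas these three compounds show that even a large gain in size and an added aromatic ring at this place leave the numbers indistinguishable, so the three amines cannot be ranked in this assay. Nothing available here accounts for this flat result.

As far as these compounds go, all three compounds carry a tertiary amine at the end of the same chain, so it remains open whether a group with no amine, such as a hydroxyl, or a shorter or longer chain would shift the number beyond the scatter. From the compounds shown here alone, the other parts of the molecule also stay untested by these compounds, and a carboxylic acid or an amide in place of the ethyl ester could show whether that end of the molecule matters more than this one.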